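The compounds below may be only part of what the source reports. "The series", "measured", "known", "first", "only" and "open" are said of these compounds alone.

Measured so far:
- compound 1, `OCc1cc(F)cc(C2=NCCCC2)c1`: 80 nM
- compound 2, `Fc1cccc(C2=NCCCC2)c1`: 108 nM
- compound 3, `Oc1cccc(C2=NCCCC2)c1`: 680 nM

All three were tested in an assay on HEK293 cells for displacement of a labelled ligand from Neuronal acetylcholine receptor; alpha3/beta4 (Homo sapiens), read by radioligand binding, with a stated time of 5 min; a higher number here means a weaker inhibitor, a lower number a stronger inhibitor. In this assay compound 3 gives 680 nM, the highest number of the three and therefore the weakest inhibitor here; the nearest is compound 2, and the gap between them, a 6.3-fold higher number from compound 2 to compound 3 (0.80 log units; beyond the scatter), lies beyond the scatter. Compound 1 gives 80 nM, lower still.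

Compound 4, `Clc1cccc(C2=NCCCC2)c1`, has not yet been measured. It differs from compound 3 in a single place: chloro in place of hydroxy on an aromatic carbon. In short, chloro in place of hydroxy on an aromatic carbon, so the hydrogen-bond donor and acceptor that hydroxy brought are gone.

The step that bears on this is a 6.3-fold higher number from compound 2 to compound 3 (0.80 log units; beyond the scatter), where a hydroxy replaced a fluoro and the number rose. Compound 4 takes that hydroxy away again and puts a chloro in its place, a group that, like fluoro, carries no hydrogen-bond donor or acceptor. The step of a 1.4-fold higher number from compound 1 to compound 2 (0.13 log units; within the scatter) concerns a different position and says little here. The expected step is therefore roughly the reverse of the fluoro-to-hydroxy change, a fall in the number, a 6.2-fold lower number from compound 3 to compound 4 (0.79 log units; beyond the scatter), beyond the scatter. Compound 4 is expected to give about 110 nM, with a range from 40 nM to 300 nM.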

Compound 4, inhibition constant: 77.2 nM
Estimate against measurement, compound 4: 1.4-fold (0.15 log units) above; low and high end bracket the measured number.
By their numbers in this assay, from the lowest: compounds 4, 1 and 2 (each within the scatter of the next); then compound 3.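

Measured by this assay, putting chloro in place of hydroxy on this aromatic carbon gives an 8.8-fold lower number from compound 3 to compound 4 (0.94 log units; beyond the scatter) and so shows that the higher number of compound 3 does not return with a second replacement of the hydroxy. The change from fluoro to chloro gives a 1.4-fold lower number from compound 2 to compound 4 (0.15 log units; within the scatter) and is within the scatter, so these two halogens cannot be told apart here, while hydroxy, the group that brings a hydrogen-bond donor and acceptor, stands alone at the higher number among compounds 2, 3 and 4. No measurement among those shown explains why hydroxy behaves differently from the two halogens.

On these data alone, it remains open whether the hydrogen of the hydroxy matters or its oxygen does, a question that a methoxy or an amine on the same carbon could help to answer. As far as these compounds go, it also remains open whether a larger group, such as trifluoromethyl or a longer carbon chain, would stay level with chloro and fluoro or move away from them.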